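This account rests on a few compounds, and the source may have more. Where it says the series, first, only, none or still open, it means among the compounds named here.

Two cytotoxicity readings exist in the series. In a functional assay on RD cells (Homo sapiens) for inhibition, read by luminescence and ATP content, with a stated time of 72 h (on this read-out higher numbers stand for lower toxicity in this test and lower numbers for higher toxicity in this test), compound 1 `CCc1nc(-c2cnc3ccc(-c4ccc(N)nc4)cc3c2)no1` gives > 66700 nM, a limit of the assay. In this assay compound 2 `CCCc1ccc(-c2ccc3ncc(-c4noc(CC)n4)cc3c2)cc1` gives > 7400 nM, also a limit of the assay. Among the compounds with values here, compound 2 therefore stands at one of two limits, and with no numbers in hand no step between measured compounds can be drawn. Compound 3 `CCc1nc(-c2cnc3ccc(-c4ccccc4)cc3c2)no1` differs from compound 2 by hydrogen in place of propyl on an aromatic carbon. In this assay no change beyond the usual scatter is expected. The estimated step is a step that the limit leaves unreadable from compound 2 to compound 3. Compound 3 is expected near 20000 nM, within 7400 nM to 66700 nM, most likely again reported only as a limit.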

Compound 3, half-maximal cytotoxic concentration: > 7400 nM
Compound 3: only a limit was reported; the forecaster's own chance of this, stated with the estimate: 80%; the middle value does not contradict the limit.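

Within the data shown here, no step from compound 1 or compound 2 to compound 3 can be read, as all three stand only as limits in this assay. Still open, as far as these compounds go, is where any of the three reaches its half-maximal cytotoxic concentration, and whether propyl or 6-aminopyridin-3-yl shifts it.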